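Removing the phenyl from a thiosemicarbazone: tolerance expected to hold

This account rests on a few compounds, and the source may have more. Where it says the series, first, only, none or still open, it means among the compounds named here.

In an ADME assay on HEL cells (Homo sapiens) for cytotoxicity (a lower number here means that less compound is tolerated, a higher number that more compound is tolerated), compound 3 `CCN(CC)CN1C(=O)/C(=N/NC(=S)Nc2ccccc2)c2ccccc21` gives > 100000 nM, which is a limit of the assay and not a number. Compound 1 `CCN(CC)CN1C(=O)/C(=N/NC(=S)Nc2ccccc2)c2cc(Cl)ccc21` gives 100000 nM in this assay. Compound 2 `CCN(CC)CN1C(=O)/C(=N/NC(N)=S)c2cc(Cl)ccc21` gives > 100000 nM, again a limit of the assay. Compound 4 `CCN(CC)CN1C(=O)/C(=N/NC(N)=S)c2ccccc21` differs from compound 3 in one place: hydrogen in place of phenyl on an amide-type nitrogen. The same change has been seen once before, as a number no lower from compound 1 to compound 2 (the limit leaves the size open), and its size is not readable because of the limit of > 100000 nM in this assay, at which 2 of the 3 values shown sit. The other known step, a number no lower from compound 1 to compound 3 (the limit leaves the size open), likewise leaves its size open. Compound 3 thus stands at the limit of this assay. Compound 4 is expected to remain there, with a step of a number no higher from compound 3 to compound 4 (the limit leaves the size open) that is estimated as none beyond the scatter. Compound 4 is estimated at 100000 nM, between 50000 nM and 100000 nM.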

Compound 4, minimum cytotoxic concentration: > 100000 nM
Compound 4 gave a limit, no number (the forecaster's own chance of this, stated with the estimate: 80%); the middle value sits exactly at the limit.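

No new step can be read from compound 3 to compound 4 or from compound 2 to compound 4, because each pair sits at the same limit: the limit of > 100000 nM in this assay, at which 3 of the 4 values shown sit.

The compounds shown leave open how much either replacement, of phenyl or of chloro by hydrogen, changes the result in this assay.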